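Hydantoin hydroxamates: removing the benzyl methyl

A few compounds are considered here, and "the series" means these few. Any claim that something is new, unique, unknown or untested is made for them only; others in the source may bear on it.

Measured compounds:
compound 1 `O=C(CCC1C(=O)N(c2ccc(Cl)cc2)C(=O)N1Cc1ccc(Br)cc1)Nc1ccc(C(=O)NO)cc1`, 4600 nM
compound 2 `Cc1ccc(CN2C(=O)N(c3ccc(Cl)cc3)C(=O)C2CCC(=O)Nc2ccc(C(=O)NO)cc2)cc1`, 14900 nM

Compound 2 `Cc1ccc(CN2C(=O)N(c3ccc(Cl)cc3)C(=O)C2CCC(=O)Nc2ccc(C(=O)NO)cc2)cc1` gives the highest of the two numbers in an assay on isolated protein for inhibition of histone deacetylase 5 (Homo sapiens), read by fluorescence, with stated times of 5 min and 60 min; a higher number here means a weaker inhibitor, a lower number a stronger inhibitor; its nearest neighbour is compound 1, which differs only at the benzyl ring and gives 4600 nM. That single step, a 3.2-fold higher number from compound 1 to compound 2 (0.51 log units; beyond the scatter), is the only one so far and shows that a change at this aromatic carbon moves the read-out modestly.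

Compound 3 `O=C(CCC1C(=O)N(c2ccc(Cl)cc2)C(=O)N1Cc1ccccc1)Nc1ccc(C(=O)NO)cc1` differs from compound 2 by hydrogen in place of methyl on an aromatic carbon. Among the compounds with values here, no measured step removes a substituent at this carbon outright; the bromo-to-methyl step only shows that the position is sensitive. With compound 2 14900 nM as anchor and compound 1 4600 nM as the other reference point, the expected step is a 1.5-fold lower number from compound 2 to compound 3 (0.17 log units; within the scatter), a modest lowering, uncertain in size. Compound 3 is estimated at 10000 nM, within 4000 nM to 25000 nM.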

Compound 3, half-maximal inhibitory concentration: 4600 nM
For compound 3 the middle estimate is 2.2-fold (0.34 log units) above the measured one; the measured number falls inside the stated range.
By their numbers in this assay, from the lowest: compounds 1 and 3 (each within the scatter of the next); then compound 2.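

In this assay, removing the methyl from the 4-methylbenzyl group gives a 3.2-fold lower number from compound 2 to compound 3 (0.51 log units; beyond the scatter) and so reverses the earlier bromo-to-methyl step in size. Hydrogen in place of bromo gives no change at the digits printed from compound 1 to compound 3 (within the scatter) on the same aromatic carbon, so bromo and hydrogen are not told apart here. Of the three groups at this carbon, only methyl stands apart from the others, and the shared core is not needed to see this since nothing else differs.

No measurement shown accounts for why methyl differs from bromo and hydrogen.

Still open, on these data alone, is whether methyl is an isolated case or one of a wider set of groups at this carbon. A methoxy, an amine, a carboxylic acid or a longer alkyl chain there would test this.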